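The source may hold more compounds than are shown below. What is called first, only, known or untested is meant among the compounds shown, and "the series" means these compounds.

Measured compounds:
Compound 1, `c1ccc(CCc2ccc3c(NCCCNCc4ccco4)ccnc3c2)cc1`, in an ADME assay for permeability, using PAMPA, with a stated time of 30 min, at pH 7.4 (on this read-out lower numbers stand for lower permeability and higher numbers for higher permeability), gives 23 10^-6 cm/s.
Compound 2, `COc1cccc(Oc2ccc3c(NCCCNCc4cc(F)ccc4OC)ccnc3c2)c1`, in this assay gives 317 10^-6 cm/s.

Of these two numbers, compound 1 has the lowest; compound 2 sits well above it, and that gap lies beyond the usual scatter of repeated measurements. Compound 3, `N#Cc1ccc(Cc2ccc3c(NCCCNCc4ccco4)ccnc3c2)cc1`, has not yet been measured. It differs from compound 1 in one place: 4-cyanophenyl in place of benzyl on a saturated chain carbon bound to an aromatic carbon. Going by the values given here, no step between two measured compounds shows what this change does, so the expectation rests on compound 1 alone. The move from benzyl to 4-cyanophenyl is expected to shift the number only slightly downward or to leave it within the scatter. The step of a 1.5-fold lower number from compound 1 to compound 3 (0.19 log units; within the scatter) is thus expected to be small. Compound 3 is estimated to give 15 10^-6 cm/s, with a likely range from 5 10^-6 cm/s to 45 10^-6 cm/s.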

Compound 3, apparent permeability: 23 10^-6 cm/s
Estimate against measurement, compound 3: 1.5-fold (0.19 log units) below; measured number inside the range.
By their numbers in this assay, from the lowest: compounds 1 and 3 (each within the scatter of the next); then compound 2.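

In this assay, putting 4-cyanophenyl in place of benzyl on a saturated chain carbon bound to an aromatic carbon gives no change at the digits printed from compound 1 to compound 3 (within the scatter). Going by these compounds alone, this is the first measured step that differs in only one place, and it shows that this position can take a nitrile, with its added hydrogen-bond acceptor, while the read-out stays level. No measurement shown here bears on why the number holds.

Going by these compounds, whether this holds for other groups is still open: a carboxylic acid or an amine on the phenyl ring in place of the nitrile could give quite a different number, and so could a longer chain carrying the ring. A single step at one position cannot show how far this tolerance extends.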